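The compounds below may be only part of what the source reports. "The series", "measured", "known", "first", "only" and "open" are said of these compounds alone.

Series notes. Compound 1 `CC1=C(/C=C/C(=O)/C=C/c2ccc(Br)cc2)C(C)(C)CCC1` gives 18900 nM in a functional assay on PC-3 cells (Homo sapiens) for cytotoxicity, read by sulforhodamine B assay, with a stated time of 48 h; on this read-out higher numbers stand for weaker inhibition and lower numbers for stronger inhibition. Within the data shown here, compound 2 `CC1=C(/C=C/C(=O)/C=C/c2ccc(C)cc2)C(C)(C)CCC1` gives 21500 nM; the single one-point step measured so far, a 1.1-fold higher number from compound 1 to compound 2 (0.06 log units; within the scatter), stays within the scatter. Compound 3 `COc1ccccc1/C=C/C(=O)/C=C/C1=C(C)CCCC1(C)C` gives 14200 nM and sits alongside compound 1 and compound 2, with all three numbers within the usual scatter of one another. Compound 4 `CC1=C(/C=C/C(=O)/C=C/c2ccccc2Br)C(C)(C)CCC1` is not yet measured; it differs from compound 3 by bromo in place of methoxy on an aromatic carbon. Only a 1.1-fold higher number from compound 1 to compound 2 (0.06 log units; within the scatter) bears on a swap of substituent on the aromatic ring, and that step was flat, so for compound 4 the expected step is a 1.1-fold higher number from compound 3 to compound 4 (0.05 log units; within the scatter), nothing beyond the scatter. Compound 4 is estimated at 16000 nM, with a range from 7000 nM to 36000 nM.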

Compound 4, half-maximal inhibitory concentration: 11400 nM
Compound 4: the middle estimate sits 1.4-fold (0.15 log units) above what was measured; low and high end bracket the measured number.
By their numbers in this assay, from the lowest: compounds 4, 3, 1 and 2 (each within the scatter of the next).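

Bromo in place of methoxy on an aromatic carbon, ortho to a large group, gives no step beyond the scatter: a 1.2-fold lower number from compound 3 to compound 4 (0.10 log units; within the scatter). The 2-bromophenyl group in place of 4-bromophenyl gives a 1.7-fold lower number from compound 1 to compound 4 (0.22 log units; within the scatter), and in place of 4-methylphenyl gives a 1.9-fold lower number from compound 2 to compound 4 (0.28 log units; within the scatter), so neither exchange separates these compounds. No measurement is at hand that could explain these results. As far as these compounds go, whether an amine or a carboxylic acid on the aromatic ring would give a step beyond the scatter remains open, as does the effect of a longer chain on the shared core.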